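The source may report more compounds than this note shows. Statements on the series, on what has been measured and on what is new or still open speak of the compounds shown alone.

Working notes on the series. The shared core of compound 1 `COc1cc(OC)c(-c2coc3cc(OCC(=O)c4cccc(C(F)(F)F)c4)ccc3c2=O)cc1OC` carries a chain bound to an oxygen on an aromatic ring, and the group on that chain is what varies here. In a functional assay on B16 cells (Mus musculus) for antiproliferative activity, read by MTT assay, with a stated time of 24 h (on this read-out lower numbers stand for stronger inhibition and higher numbers for weaker inhibition), compound 1 gives > 10000 nM, which is a limit of the assay and not a number (the limit of > 10000 nM in this assay, at which 1 of the 3 values shown sits). Compound 2 `COc1cc(OC)c(-c2coc3cc(OCc4ccccc4C)ccc3c2=O)cc1OC` gives 2150 nM in this assay. Compound 3 `COc1cc(OC)c(-c2coc3cc(OCc4ccccc4C(F)(F)F)ccc3c2=O)cc1OC` gives 8550 nM in this assay. Against the limit of compound 1, there is an at least 4.6-fold lower number from compound 1 to compound 2 (0.66 log units; beyond the scatter), and an at least 1.1-fold lower number from compound 1 to compound 3 (0.06 log units; that floor lies within the scatter). Within the pair of measured aryl groups there is a 4.0-fold higher number from compound 2 to compound 3 (0.60 log units; beyond the scatter).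

Compound 4 `COc1cc(OC)c(-c2coc3cc(OCc4ccccc4Br)ccc3c2=O)cc1OC` has not been measured. Against compound 1 the change is 2-bromophenyl in place of (3-(trifluoromethyl)phenyl)carbonyl on a saturated chain carbon bound to an oxygen on an aromatic ring. The two steps out of compound 1 both replace the same carbonyl-bearing group with a 2-substituted phenyl on the chain, so both bear on this step; one is modest and beyond the scatter, the other carries a limit that lies within the scatter. Since 2-bromophenyl matches neither 2-methylphenyl nor 2-(trifluoromethyl)phenyl, compound 4 is expected to land inside the span of compound 2 and compound 3, a lower number than the limit of compound 1 without a strong pull. Compound 4 is therefore estimated at 4200 nM, with a range of 1500 nM to 12000 nM. This estimate means an expected at least 2.3-fold lower number from compound 1 to compound 4 (0.37 log units; beyond the scatter).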

Compound 4, half-maximal inhibitory concentration: 8900 nM
Beside the measured number, compound 4's estimate is 2.1-fold (0.33 log units) below it; measured number inside the range.
By their numbers in this assay, from the lowest: compound 2; then compounds 3 and 4 (each within the scatter of the next). At a limit, above all of these: compound 1.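

Bromo in place of trifluoromethyl on an aromatic carbon gives a 1.0-fold higher number from compound 3 to compound 4 (0.02 log units; within the scatter) in this assay, so compounds 3 and 4 cannot be told apart at this place. Bromo in place of methyl gives a 4.1-fold higher number from compound 2 to compound 4 (0.62 log units; beyond the scatter), a step of much the same size as a 4.0-fold higher number from compound 2 to compound 3 (0.60 log units; beyond the scatter), so among the three measured aryl groups on the chain, compound 2, with its methyl, stands apart from the other two. Compound 1 stands at a limit of the assay and not a number, so an at least 1.1-fold lower number from compound 1 to compound 4 (0.05 log units; that floor lies within the scatter) is only a floor that does not part compound 4 from it: the limit of > 10000 nM in this assay, at which 1 of the 4 values shown sits.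

On these data alone, whether an amine or a methoxy on the phenyl ring in place of the methyl would stay with compound 2 or fall with compounds 3 and 4 remains open. As far as these compounds go, compound 1 also differs from the others in both the carbonyl and the aryl group at once, so what the carbonyl alone contributes on the chain remains open as well.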